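Bromine Position on the Anilino Ring: Compound 4 Estimate

The source may report more compounds than this note shows. Statements on the series, on what has been measured and on what is new or still open speak of the compounds shown alone.

Measured compounds:
- compound 1 `CCc1cccc(Nc2cc(NC(=O)Nc3cc(OC)cc(OC)c3)ncn2)c1`, 27.7%
- compound 2 `COc1cc(NC(=O)Nc2cc(Nc3cc(I)ccc3OC)ncn2)cc(OC)c1`, 59%
- compound 3 `COc1cc(NC(=O)Nc2cc(Nc3ccc(Br)cc3OC)ncn2)cc(OC)c1`, 20.1%

In a functional assay on NCI-H1581 cells (Homo sapiens) for inhibition, read by MTT assay, with a stated time of 48 h, tested at 10 uM (on this read-out higher numbers stand for more inhibition at the one concentration tested (going by the name of the read-out) and lower numbers for less inhibition), compound 3 gives 20.1%, the lowest of the three numbers. Its nearest neighbour is compound 1, and the gap between them (a number 7.6 percentage points lower from compound 1 to compound 3 (within the scatter)) lies within the scatter, so no order between compound 1 and compound 3 is claimed. Its furthest neighbour is compound 2, with a number 38.9 percentage points lower from compound 2 to compound 3 (beyond the scatter), a large drop.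

Compound 4 `COc1cc(NC(=O)Nc2cc(Nc3cc(Br)ccc3OC)ncn2)cc(OC)c1` is not yet measured in this assay. It differs from compound 3 by 5-bromo-2-methoxyphenyl in place of 4-bromo-2-methoxyphenyl on a nitrogen on an aromatic ring. The atoms are the same; only the bromine moves on the ring.

Within the data shown here, two measured steps bear on this. The step of a number 38.9 percentage points lower from compound 2 to compound 3 (beyond the scatter) moves a halogen from the 5-position of the methoxyphenyl ring to the 4-position and loses heavily, while a number 31.3 percentage points higher from compound 1 to compound 2 (beyond the scatter) shows the 5-iodo-2-methoxyphenyl arrangement gaining strongly over 3-ethylphenyl. Compound 4 restores the 5-halo, 2-methoxy pattern of compound 2, with bromine rather than iodine. A rise beyond the scatter is therefore expected from compound 3 to compound 4, estimated as a number 27.9 percentage points higher from compound 3 to compound 4 (beyond the scatter), though no direct bromine-for-iodine comparison exists here. Compound 4 is expected to give about 48%, within 25% to 68%.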

Compound 4, a percentage reported as inhibition, at one concentration (the size of the read-out at that concentration, not a potency): 23.1%
Beside the measured number, compound 4's estimate is 24.9 percentage points above it; measured number outside the range, below it.
By their numbers in this assay, from the lowest: compounds 3, 4 and 1 (each within the scatter of the next); then compound 2.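

Working notes on the anilino ring. In this assay the change from 4-bromo-2-methoxyphenyl to 5-bromo-2-methoxyphenyl on the nitrogen gives a number 3 percentage points higher from compound 3 to compound 4 (within the scatter) and so makes no readable difference with bromo in the series, while a number 4.6 percentage points lower from compound 1 to compound 4 (within the scatter) leaves compound 4 and the 3-ethylphenyl compound without any claimed order. Among these compounds, the 5-halo-2-methoxyphenyl arrangement therefore does not by itself give the high number of compound 2: the single exchange in a number 35.9 percentage points lower from compound 2 to compound 4 (beyond the scatter) is a large step, and it shows that at this place on the ring the high number is seen with iodo and not with bromo, a statement that rests on this one pair of compounds. No measurement at hand gives a reason for the gap between iodo and bromo.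

Still open, on these data alone, is whether iodo is unique at this place or whether other groups there, such as chloro, methyl, trifluoromethyl or a nitrile, would also reach the level of compound 2. Also open, as far as these compounds go, is what 4-iodo-2-methoxyphenyl would give, which would show whether moving the halogen matters when that halogen is iodo.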